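The compounds below may be only part of what the source reports. "The series", "measured", "known", "first", "only" and "open" are said of these compounds alone.

Measured compounds:
Compound 1 `Cc1ccccc1-n1nncc1CN1C(=O)C2(C(C#N)=C(N)Oc3c2c2nc4ccccc4nc2c2ccccc32)c2ccccc21` gives > 50000 nM in a functional assay on HCT-116 cells (Homo sapiens) for antiproliferative activity, read by MTT assay, with a stated time of 48 h; a lower number here means a stronger inhibitor, a higher number a weaker inhibitor; this value is a limit of the assay and not a number.
Compound 2 `N#CC1=C(N)Oc2c(c3nc4ccccc4nc3c3ccccc23)C12C(=O)N(Cc1cnnn1-c1ccccc1Br)c1ccccc12` gives > 50000 nM in this assay ; this value is a limit of the assay and not a number.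
Compound 3 `CCOc1ccccc1-n1nncc1CN1C(=O)C2(C(C#N)=C(N)Oc3c2c2nc4ccccc4nc2c2ccccc32)c2ccccc21` gives > 50000 nM in this assay ; this value is a limit of the assay and not a number.

Compound 2 therefore stands only at a limit in this assay, as do the other two values shown; all three sit at the limit of > 50000 nM in this assay, at which 3 of the 3 values shown sit. Compound 4 `Cc1ccc(C)c(-n2nncc2CN2C(=O)C3(C(C#N)=C(N)Oc4c3c3nc5ccccc5nc3c3ccccc43)c3ccccc32)c1` differs from compound 2 by 2,5-dimethylphenyl in place of 2-bromophenyl on an aromatic nitrogen. The measured steps that touch the same phenyl ring are a step that the two limits leave unreadable from compound 1 to compound 2, a step that the two limits leave unreadable from compound 2 to compound 3 and a step that the two limits leave unreadable from compound 1 to compound 3; none of them can be read in size, as both ends of each sit at the limit of > 50000 nM in this assay, at which 3 of the 3 values shown sit. Nothing in these numbers separates one substituent on that ring from another, so no step beyond the scatter in either direction is expected in this assay . Compound 4 is accordingly expected to give 60000 nM (range 20000 nM to 200000 nM), most likely reported again only as a limit. The step from compound 2 to compound 4 is thus estimated as a step that the limit leaves unreadable from compound 2 to compound 4.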

Compound 4, half-maximal inhibitory concentration: > 50000 nM
Compound 4 was reported as a limit (the forecaster's own chance of this, stated with the estimate: 80%); the middle value does not contradict the limit.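

Compound 4 gives > 50000 nM in this assay, which is a limit of the assay and not a number. None of the steps from compound 1, compound 2 or compound 3 to compound 4 can be read in size: the limit of > 50000 nM in this assay, at which 4 of the 4 values shown sit. The compounds shown leave open how the substituents on this phenyl ring compare with one another in this assay.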